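This account rests on a few compounds, and the source may have more. Where it says the series, first, only, none or still open, it means among the compounds named here.

In an ADME assay on THP-1 cells (Homo sapiens) for cytotoxicity, read by MTT assay (a higher number here means that more compound is tolerated, a lower number that less compound is tolerated), compound 1 `Cc1nc(-c2cccnc2)sc1-c1nnc(-c2cccc(Cl)c2Cl)o1` gives > 100 ug/mL, which is a limit of the assay rather than a measured number. Compound 2 `Cc1cccc(-c2nnc(-c3sc(-c4cccnc4)nc3C)o2)c1` likewise gives only a limit in this assay, > 100 ug/mL. Compound 3 `Cc1ccc(-c2nnc(-c3sc(-c4cccnc4)nc3C)o2)cc1` also stands at a limit in this assay, > 100 ug/mL. For the measured compounds named here, because all three values sit at the limit of > 100 ug/mL in this assay, at which 3 of the 3 values shown sit, no step among them can be read: a step that the two limits leave unreadable from compound 1 to compound 2, a step that the two limits leave unreadable from compound 1 to compound 3 and a step that the two limits leave unreadable from compound 2 to compound 3 each stay without a readable size, so nothing is known about whether exchanging the group on that aromatic carbon of the shared core moves the tolerated concentration at all.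

Compound 4 `Cc1ccccc1-c1nnc(-c2sc(-c3cccnc3)nc2C)o1` has not yet been measured. It differs from compound 3 in one place: 2-methylphenyl in place of 4-methylphenyl on an aromatic carbon. Going by the values given here, the steps that bear on this exchange are the three just mentioned, and none of them shows a size. The expectation for compound 4 in this assay is therefore a step of no readable size, a step that the limit leaves unreadable from compound 3 to compound 4, with the value most likely reported again as a limit. The estimate for compound 4 in this assay is 150 ug/mL, with a range from 70 ug/mL to 400 ug/mL.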

Compound 4, half-maximal cytotoxic concentration: > 100 ug/mL
Compound 4 was reported as a limit; the forecaster's own chance of this, stated with the estimate: 85%; the middle value lies beyond the limit too.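

In this assay compound 4 gives > 100 ug/mL as a limit of the assay and not a number. For the compounds shown here, no step between compound 4 and compound 1, compound 2 or compound 3 can be read, because all four compounds share one limit: the limit of > 100 ug/mL in this assay, at which 4 of the 4 values shown sit. The compounds shown leave open whether exchanging the group on that aromatic carbon changes the tolerated concentration at all.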